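Swapping the sulfonyl phenyl for a bridged bicyclic amine

The compounds below may be only part of what the source reports. "The series", "measured", "known", "first", "only" and "open" are said of these compounds alone.

Compound 1 `N#C/N=C(\NCc1ccc(S(=O)(=O)c2ccccc2)cc1)Nc1cccnc1` is the reference here. In an assay on isolated protein for inhibition of Nicotinamide phosphoribosyltransferase (Homo sapiens), read by mass spectrometry, with stated times of 15 min and 30 min (a lower number here means a stronger inhibitor, a higher number a weaker inhibitor), compound 1 gives 2.2 nM, the lowest of the two numbers available. Compound 2 `N#C/N=C(\NCc1ccc(S(=O)(=O)c2ccccc2)cc1)Nc1ccncc1`, which carries pyridin-4-yl in place of pyridin-3-yl on the amine nitrogen, gives 2.5 nM in this assay, and the step of a 1.1-fold higher number from compound 1 to compound 2 (0.06 log units; within the scatter) lies within the scatter. The unmeasured compound 3 `N#C/N=C(\NCc1ccc(S(=O)(=O)N2CC3CCC(C2)O3)cc1)Nc1cccnc1` differs from compound 1 at the other end of the shared core: a group of 8 heavy atoms (6 carbon, 1 nitrogen, 1 oxygen; one five-membered non-aromatic ring with 1 hetero atom, one six-membered non-aromatic ring with 2 hetero atoms) in place of a group of 6 heavy atoms (6 carbon; one six-membered aromatic ring of carbon only), on a sulfonyl sulfur. Among the compounds with values here, no measured step touches the sulfonyl substituent, so the only step on record, a 1.1-fold higher number from compound 1 to compound 2 (0.06 log units; within the scatter), offers no guide for this change. With nothing to anchor it, a modest loss is expected for compound 3, a 2.3-fold higher number from compound 1 to compound 3 (0.36 log units; beyond the scatter), with wide uncertainty. Compound 3 is estimated at 5 nM in this assay, between 1.5 nM and 20 nM.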

Compound 3, half-maximal inhibitory concentration: 4.4 nM
The estimate for compound 3 lay 1.1-fold (0.06 log units) above the measured number; measured number inside the range.
By their numbers in this assay, from the lowest: compounds 1, 2 and 3 (each within the scatter of the next).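

At the sulfonyl sulfur, the step of a 2.0-fold higher number from compound 1 to compound 3 (0.30 log units; within the scatter) in this assay shows that this position accepts far more than a change of the carbon-only aromatic ring: phenyl gives way to a group with two non-aromatic rings, with nitrogen now on the sulfur and one hydrogen-bond acceptor added, and the number stays within the scatter. The aromatic phenyl is therefore not needed at this position for a low nanomolar number in compound 3, something compounds 1 and 2, which share that phenyl, could not show. No evidence on record accounts for this result.

The compounds shown leave open how a morpholine or a plain dimethylamino group on the sulfonyl sulfur would read. They also leave open whether the new group behaves the same way alongside pyridin-4-yl on the amine nitrogen.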